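Isobutyl to methyl in the series

This account rests on a few compounds, and the source may have more. Where it says the series, first, only, none or still open, it means among the compounds named here.

Measured in a physicochemical assay for solubility, in phosphate buffer, at pH 7.4; a higher number here means a more soluble compound, a lower number a less soluble compound:
- compound 1 `CC(C)Cn1cc(-c2ccnc3[nH]c(C4CCN(CC(=O)N(C)C)CC4)cc23)ccc1=O` (390000 nM)
- compound 2 `COc1cc(F)ccc1-c1ccnc2[nH]c(C3CCN(C(C)=O)CC3)cc12` (50000 nM)

Compound 1 (390000 nM) stands highest of the two, and the gap to compound 2 (50000 nM) is outside the scatter. Compound 3 `CN(C)C(=O)CN1CCC(c2cc3c(-c4ccc(=O)n(C)c4)ccnc3[nH]2)CC1` departs from compound 1 by one change (hydrogen in place of isopropyl on a saturated chain carbon bound to an aromatic nitrogen), with hydrogen in place of isopropyl on a saturated chain carbon bound to an aromatic nitrogen. Among the measured compounds shown here, no measured pair shows this change, so the size of the step is uncertain. A modest rise in this assay is expected, possibly none beyond the scatter. The estimated step is small (a 1.4-fold higher number from compound 1 to compound 3 (0.15 log units; within the scatter)) and upward. The expected value for compound 3 is 550000 nM (estimated range 200000 nM to 1200000 nM).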

Compound 3, solubility: > 1000000 nM
Compound 3 ended at the assay's limit; the forecaster's own chance of this, stated with the estimate: 15%; middle value at least 1.8-fold (0.25 log units) from the limit.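

At this position, on a saturated chain carbon bound to an aromatic nitrogen, hydrogen in place of isopropyl (isobutyl to methyl) gives an at least 2.5-fold higher number from compound 1 to compound 3 (0.40 log units; beyond the scatter) in this assay. Compound 3 reads > 1000000 nM, which is a limit of the assay and not a number. The step is therefore a minimum, and its full size stays unread because the read-out ends there: the limit of > 1000000 nM in this assay, at which 1 of the 3 values shown sits.

Open, on these data alone, is whether an ethyl group or a longer chain carrying a hydroxyl or an amine at this position would also reach the limit. Also open, as far as these compounds go, is whether the same change would give a similar step on compound 2's side of the series, which carries a different group here.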